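This account rests on a few compounds, and the source may have more. Where it says the series, first, only, none or still open, it means among the compounds named here.

In a functional assay on BGC-823 cells (Homo sapiens) for inhibition, read by CCK-8 assay, with a stated time of 48 h (on this read-out lower numbers stand for stronger inhibition and higher numbers for weaker inhibition), the measured compounds are:

Compound 1 `Cc1ccc(C2=NN(C3=NC(c4ccccc4)CS3)C(c3ccc4ccccc4c3)C2)cc1`: 8940 nM
Compound 2 `Fc1ccc(C2=NN(C3=NC(c4ccccc4)CS3)C(c3ccc4ccccc4c3)C2)cc1`: 17300 nM
Compound 3 `O=C1CSC(N2N=C(c3ccc(F)cc3)CC2c2ccc3ccccc3c2)=N1`: 14900 nM

Compound 3 lies within the scatter of both compound 1 and compound 2, so these three values cannot be ordered. Compound 4 `O=C1CSC(N2N=C(c3ccc(Cl)cc3)CC2c2ccc3ccccc3c2)=N1` differs from compound 3 by chloro in place of fluoro on an aromatic carbon, para to a large group. The closest measured change, also on an aromatic carbon, is a 1.9-fold higher number from compound 1 to compound 2 (0.29 log units; within the scatter). The change on the amine nitrogen in a ring is a 1.2-fold lower number from compound 2 to compound 3 (0.06 log units; within the scatter). Both lie within the scatter, so no step beyond it is expected in this assay. The expected step is a 1.1-fold lower number from compound 3 to compound 4 (0.06 log units; within the scatter). Compound 4 is estimated at 13000 nM, with an expected range of 6000 nM to 28000 nM.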

Compound 4, half-maximal inhibitory concentration: 13200 nM
Compound 4: the middle estimate sits 1.0-fold (0.01 log units) below what was measured, within the range that was stated.
By their numbers in this assay, from the lowest: compounds 1, 4, 3 and 2 (each within the scatter of the next).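

In this assay, the change from 4-fluorophenyl to 4-chlorophenyl gives a 1.1-fold lower number from compound 3 to compound 4 (0.05 log units; within the scatter). The earlier step at this position, a 1.9-fold higher number from compound 1 to compound 2 (0.29 log units; within the scatter), exchanged methyl for fluoro on a different group at the amine nitrogen, whereas this one exchanges one halogen for another with the carbonyl-containing ring in place. Both steps lie within the scatter, and no available evidence bears on why this position responds so little. Still open, going by these compounds, is whether an amine or a carboxylic acid at this position would give a step beyond the scatter. Also open, on these data alone, is whether chloro would give a similar result with the phenyl-bearing ring of compound 2.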